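Trimming a Methyl on the Way from Compound 3 to Compound 4

This account rests on a few compounds, and the source may have more. Where it says the series, first, only, none or still open, it means among the compounds named here.

Three compounds sharing one core have been examined in an ADME assay on the whole organism (strain Han-Wistar) for pharmacokinetics, with Rattus norvegicus as the target, read by LC-MS, at a dose of 2 mg/kg by the oral route; a lower number here means less compound in the circulation, a higher number more compound in the circulation at the dose given. Compound 1 `CN1CCN(CCCS(=O)(=O)c2ccc3nc(NC(=O)NC(=O)c4cccc(-n5cccn5)c4Cl)sc3c2)CC1` gives 12 nM in this assay, and compound 2 `CN1CCN(CCCS(=O)(=O)c2ccc3nc(NC(=O)NC(=O)c4cc(-n5cccn5)c(Cl)cc4Cl)sc3c2)CC1` gives 30 nM. Compound 3 `Cc1cc(C)n(-c2ccc(Cl)c(C(=O)NC(=O)Nc3nc4ccc(S(=O)(=O)CCCN5CCN(C)CC5)cc4s3)c2)n1` stands highest of the three, giving 78 nM in this assay; its nearest neighbour is compound 2, which lies beyond the scatter below it, and the gap to compound 1 is wider still, also beyond the scatter.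

Compound 4 `Cc1ccn(-c2ccc(Cl)c(C(=O)NC(=O)Nc3nc4ccc(S(=O)(=O)CCCN5CCN(C)CC5)cc4s3)c2)n1` has not yet been measured. It differs from compound 3 in one place: hydrogen in place of methyl on an aromatic carbon, so that the 3,5-dimethyl-1H-pyrazol-1-yl group of compound 3 becomes a 3-methyl-1H-pyrazol-1-yl group in compound 4. Among the measured compounds shown here, no pair of measured compounds shows what such a removal of a methyl does to the maximal plasma concentration, so the direction of the change cannot be read from the data. The step from compound 3 to compound 4 is expected to be a 1.3-fold lower number from compound 3 to compound 4 (0.11 log units; within the scatter), that is, none beyond the scatter. Compound 4 is therefore estimated at 60 nM in this assay, within a range from 20 nM to 180 nM.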

Compound 4, maximal plasma concentration: 410 nM
Compound 4: the middle estimate sits 6.8-fold (0.83 log units) below what was measured; measured number outside the range, above it.
By their numbers in this assay, from the lowest: compound 1; then compound 2; then compound 3; then compound 4.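

Among the compounds shown here, removing the methyl next to the ring atom that bears a large group gives the first direct reading of this position: in this assay, the change produces a 5.3-fold higher number from compound 3 to compound 4 (0.72 log units; beyond the scatter). Across this one pair, the maximal plasma concentration therefore responds to the loss of a single carbon, with the 3,5-dimethyl-1H-pyrazol-1-yl group giving way to the 3-methyl-1H-pyrazol-1-yl group and the rest of the molecule unchanged. Nothing given here bears on what lies behind this rise.

This is the only pair shown that differs in one place, so whether the same removal acts alike on other members of the series remains open. As far as these compounds go, it also remains open how an ethyl group, a chlorine atom or a methoxy group at this position would compare with hydrogen and methyl.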